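Ortho-methyl on the anilide of compound 2

The source may hold more compounds than are shown below. What is called first, only, known or untested is meant among the compounds shown, and "the series" means these compounds.

Measured compounds:
- Compound 1, `O=C(O)CCc1nnc(C(=O)Nc2cccc(-c3cccc(Cl)c3)c2)s1`, in a functional assay on CHO cells for agonist activity at Free fatty acid receptor 1 (Homo sapiens), read by calcium flux; a lower number here means that less compound is needed, a higher number that more compound is needed for the effect: 1690 nM
- Compound 2, `O=C(O)CCc1ccc(OCc2nnc(C(=O)Nc3ccccc3)s2)cc1`, in this assay: 1060 nM

The two numbers sit within the usual scatter of each other, so compound 2 cannot be set apart from compound 1 on these data. Compound 3, `Cc1ccccc1NC(=O)c1nnc(COc2ccc(CCC(=O)O)cc2)s1`, differs from compound 2 by methyl in place of hydrogen on an aromatic carbon. Within the data shown here, no measured pair shows this change, so no step size is known for it; a small shift, not clearly beyond the scatter, is the expectation. Compound 3 is therefore estimated at 1000 nM, between 400 nM and 2500 nM, an expected step of a 1.1-fold lower number from compound 2 to compound 3 (0.03 log units; within the scatter).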

Compound 3, half-maximal effective concentration: 1520 nM
The estimate for compound 3 lay 1.5-fold (0.18 log units) below the measured number; the measured number falls inside the stated range.
By their numbers in this assay, from the lowest: compounds 2, 3 and 1 (each within the scatter of the next).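

Replacing phenyl with 2-methylphenyl on the amide of compound 2 gives compound 3 in this assay (a 1.4-fold higher number from compound 2 to compound 3 (0.16 log units; within the scatter)), so a methyl is tolerated at this position, with no shift that can be told from the scatter. This first step on this ring gives no direction for the change. No measurement offered here explains the result. As far as these compounds go, whether a chlorine or an amine in the same place would move the number beyond the scatter stays open, as does whether a larger group than methyl would.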